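The source may hold more compounds than are shown below. What is called first, only, known or untested is meant among the compounds shown, and "the series" means these compounds.

Compound 1 `CCN(CC)C(=O)c1ccc(NC(=O)C(C)(O)C(F)(F)F)cc1` carries the shared core with a diethylcarbamoyl group. In an assay on a protein complex (Cavia porcellus) with sulfonylurea receptors; K-ATP channels (Homo sapiens) as the target (a lower number here means a stronger inhibitor, a higher number a weaker inhibitor), compound 1 gives only a limit of the assay, > 30000 nM, and no number. Compound 2 `CCC(C)N(C(C)CC)S(=O)(=O)c1ccc(NC(=O)C(C)(O)C(F)(F)F)cc1` likewise gives only a limit, > 30000 nM, in this assay. Compound 1 therefore stands where every measured value in this set stands: the limit of > 30000 nM in this assay, at which 2 of the 2 values shown sit. Compound 3 `Cn1nnnc1-c1ccc(NC(=O)C(C)(O)C(F)(F)F)cc1` is still to be measured in this assay. It differs from compound 1 by 1-methyl-1H-tetrazol-5-yl in place of diethylcarbamoyl on an aromatic carbon. No comparable change has been measured, and both known values are limits, so the numbers give no direction. The expected step of a number no higher from compound 1 to compound 3 (the limit leaves the size open) is none beyond the usual scatter. Compound 3 is estimated to give 30000 nM in this assay, within a range from 5000 nM to 100000 nM, most likely again reported only as a limit.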

Compound 3, half-maximal inhibitory concentration: 30900 nM
Estimate against measurement, compound 3: 1.0-fold (0.01 log units) below; measured number inside the range.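

Within the data shown here, no step from compound 1 to compound 3 can be read: compound 1 is reported only as the limit > 30000 nM and not as a number. Still open, as far as these compounds go, is whether in this assay any group on the shared core gives a clearly stronger inhibitor, and how far diethylcarbamoyl and 1-methyl-1H-tetrazol-5-yl really differ.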